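The source may hold more compounds than are shown below. What is called first, only, known or untested is meant among the compounds shown, and "the series" means these compounds.

Compound 1 `CCc1cc2c(C(=O)c3ccc(OC)cc3)c(OC)ccc2o1` gives 6.1% in an assay for inhibition of solute carrier family 22 member 12 (Homo sapiens), read by scintillation counting, with a stated time of 60 min, tested at 50 uM; on this read-out lower numbers stand for less inhibition and higher numbers for more inhibition at the one concentration tested (going by the name of the read-out). Compound 2 `CCc1cc2c(C(=O)c3ccc(O)cc3)c(OC)ccc2o1` gives 88.2% in this assay; the change hydrogen in place of methyl on an oxygen on an aromatic ring produced a step of a number 82.1 percentage points higher from compound 1 to compound 2 (beyond the scatter). Compound 3 `CCc1oc2cc(O)ccc2c1C(=O)c1ccc(OC)cc1` gives 48.3% in this assay; the difference between the cores of compound 1 and compound 3 is not broken down here. Compound 4 `CCc1oc2cc(O)ccc2c1C(=O)c1ccc(O)cc1` is the unmeasured member, differing from compound 3 by hydrogen in place of methyl on an oxygen on an aromatic ring, the same change that led from compound 1 to compound 2 with an identical surrounding place. Because compound 3 already gives 48.3% and the number in this read-out cannot go much higher, the expected step in this assay is smaller than the earlier one, at about a number 39.7 percentage points higher from compound 3 to compound 4 (beyond the scatter). Compound 4 is therefore estimated at 88%, between 68% and 99%.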

Compound 4, a percentage reported as inhibition, at one concentration (the size of the read-out at that concentration, not a potency): 92.1%
Beside the measured number, compound 4's estimate is 4.1 percentage points below it; the range from low to high includes it.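

On the core of compound 3, methoxy to hydroxy gives a number 43.8 percentage points higher from compound 3 to compound 4 (beyond the scatter) in this assay, so the change raises the number on this core as well. The direction carries from one core to the other, but the size does not: the same change on two cores in this assay, a number 82.1 percentage points higher (beyond the scatter) from compound 1 to compound 2 and a number 43.8 percentage points higher (beyond the scatter) from compound 3 to compound 4, 38.3 percentage points apart, beyond the scatter of two such steps. Two cores give no rule for a third, and these pairs do not tell whether the gap between the steps comes from the core itself or from the limited room at the top of a percentage read-out.

Still open, as far as these compounds go, is how a carboxylic acid or an amine would compare with the hydroxy on the aromatic ring. Also open, from the compounds shown here alone, is what a longer chain in place of the ethyl group would do.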